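Swapping a para methyl for chloro on compound 1

A few compounds are considered here, and "the series" means these few. Any claim that something is new, unique, unknown or untested is made for them only; others in the source may bear on it.

Compound 1 `COc1ccc2cc(C(C)c3nnc4n3N=C(c3ccc(C)cc3)CS4)ccc2c1` is the weakest of the three measured compounds in a functional assay on HCT-116 cells (Homo sapiens) for inhibition, read by sulforhodamine B assay, with a stated time of 72 h; a higher number here means a weaker inhibitor, a lower number a stronger inhibitor: compound 1 gives 10200 nM, a number beyond the usual scatter above both neighbours. Compound 2 `Cc1ccc(C2=Nn3c(nnc3C(C)c3ccc(-c4ccccc4)c(F)c3)SC2)cc1` gives 4800 nM in this assay, and compound 3 `COc1ccc(C2=Nn3c(nnc3C(C)c3ccc(-c4ccccc4)c(F)c3)SC2)cc1` gives 4400 nM. The only single-point step among these is from compound 2 to compound 3, a 1.1-fold lower number from compound 2 to compound 3 (0.04 log units; within the scatter), showing that exchanging one small group on the outer phenyl ring left the number essentially unchanged.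

Compound 4 `COc1ccc2cc(C(C)c3nnc4n3N=C(c3ccc(Cl)cc3)CS4)ccc2c1` differs from compound 1 by chloro in place of methyl on an aromatic carbon. That is the same kind of change the measured step covers: a small substituent on the outer phenyl ring replaced by another small substituent, while the shared core and the other side arm stay untouched. The step from compound 2 to compound 3 was within the scatter, so the expectation for compound 4 is a change that stays within or only just beyond the scatter, with no firm direction.

Compound 4 is therefore estimated at 8000 nM in this assay, with a range from 3500 nM to 18000 nM, which corresponds to an expected step of a 1.3-fold lower number from compound 1 to compound 4 (0.11 log units; within the scatter).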

Compound 4, half-maximal inhibitory concentration: 8800 nM
Compound 4: middle estimate off by 1.1-fold (0.04 log units), on the low side, within the range that was stated.
By their numbers in this assay, from the lowest: compounds 3, 2, 4 and 1 (each within the scatter of the next, the first and the last beyond it).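

Exchanging 4-methylphenyl for 4-chlorophenyl gives a 1.2-fold lower number from compound 1 to compound 4 (0.06 log units; within the scatter) in this assay, so this position tolerates a chlorine in place of a methyl carbon with no readable shift in the number. The earlier single-place step, a 1.1-fold lower number from compound 2 to compound 3 (0.04 log units; within the scatter), came from a series with a different side arm and brought in methoxy, so the new step adds a second group and a second side arm to the same picture: a small group exchanged on this outer ring has so far stayed within the scatter, in both pairs that can be read. Nothing measured here accounts for how little the number responds to this exchange.

Going by these compounds, all of these exchanges involve small groups, so it remains open whether an amine, a carboxylic acid or a longer chain such as butyl at the same place would move the number beyond the scatter. On these data alone, it is also open whether chloro would behave the same way on the side arm that compound 2 carries, since a single pair cannot show how far this result extends.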